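The source may report more compounds than this note shows. Statements on the series, on what has been measured and on what is new or still open speak of the compounds shown alone.

Among the three compounds measured so far, compound 1 `CCC(CC)N(CCN(C)C(=O)CCC(=O)O)Cc1cccc(C(=O)Nc2sc3c(c2C(=O)c2cnn(-c4ccc(Cl)c(C(F)(F)F)c4)c2)CCC(C)(C)C3)c1` stands at the lowest number: in an assay on isolated protein for inhibition of sodium-dependent phosphate transport protein 2B (Homo sapiens) (on this read-out lower numbers stand for stronger inhibition and higher numbers for weaker inhibition), compound 1 gives 38 nM. The nearest of the other two is compound 3 `CCC(CC)N(CCN(C)C(=O)CCC(=O)O)Cc1cccc(C(=O)Nc2sc3c(c2C(=O)c2cnn(-c4ccc(Cl)cc4)c2)CCN(C2CC2)C3)c1`, which in this assay gives 80 nM, a gap beyond the usual scatter. Furthest is compound 2 `CCC(CC)N(CCN(C)C(=O)CCC(=O)O)Cc1cccc(C(=O)Nc2sc3c(c2C(=O)c2cnn(-c4ccc(Cl)cc4)c2)CCCC3)c1`, which in this assay gives 118 nM, also beyond the scatter. Among the measured compounds shown here, none of these pairs differs in a single place, so no measured step of a single change is available as a guide.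

Compound 4 `CCC(CC)N(CCN(C)C(=O)CCC(=O)O)Cc1cccc(C(=O)Nc2sc3c(c2C(=O)c2cnn(-c4cccc(C(F)(F)F)c4)c2)CCC(C)(C)C3)c1` differs from compound 1 in one place only: hydrogen in place of chloro on an aromatic carbon. Compounds 2 and 3 carry a 4-chlorophenyl on the same side of the shared core, but they differ from compound 1 in further places as well, so their numbers say nothing clean about removing the chloro alone. On that basis the step from compound 1 to compound 4 is expected to be a small loss, estimated at a 1.7-fold higher number from compound 1 to compound 4 (0.23 log units; within the scatter), likely near the edge of the scatter. Compound 4 is therefore expected to give about 65 nM in this assay, within a range of 25 nM to 170 nM.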

Compound 4, half-maximal inhibitory concentration: 46 nM
Beside the measured number, compound 4's estimate is 1.4-fold (0.15 log units) above it, within the range that was stated.
By their numbers in this assay, from the lowest: compounds 1, 4, 3 and 2 (each within the scatter of the next, the first and the last beyond it).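

Putting hydrogen in place of chloro on this aromatic carbon, ortho to a trifluoromethyl group, gives a 1.2-fold higher number from compound 1 to compound 4 (0.08 log units; within the scatter) in this assay. The change from 4-chloro-3-(trifluoromethyl)phenyl to 3-(trifluoromethyl)phenyl therefore leaves the number within the usual scatter on this core, with the trifluoromethyl group in place. The earlier compounds shown here could not show this, since compounds 2 and 3 differ from compound 1 in further places as well.

From the compounds shown here alone, it remains open whether a fluoro, a methoxy, an amine or a nitrile at this position would also stay within the scatter of compound 1, and whether chloro and hydrogen would read alike without the trifluoromethyl group. Nothing shown here bears on why chloro and hydrogen read alike at this position.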